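A few compounds are considered here, and "the series" means these few. Any claim that something is new, unique, unknown or untested is made for them only; others in the source may bear on it.

In a functional assay on MCF7 cells (Homo sapiens) for antiproliferative activity (on this read-out lower numbers stand for stronger inhibition and higher numbers for weaker inhibition), compound 1 (`CCCCOc1ccc(C(=O)Nc2cc3ccc(OC4CCN(C)CC4)c(C)c3oc2=O)cc1CC=C(C)C`) gives 1440 nM. Compound 3 (`C=CCc1cc(C(=O)Nc2cc3ccc(OC4CCN(C)CC4)c(C)c3oc2=O)ccc1OC(C)=O`) gives 2000 nM, which lies within the scatter of compound 1, so the two cannot be told apart. Compound 2 (`Cc1c(OC2CCN(C)CC2)ccc2cc(NC(=O)c3ccc4c(c3)CCC(C)(C)O4)c(=O)oc12`) stands apart at 5010 nM, beyond the scatter above compound 1.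

Compound 4 (`CC(C)=CCc1cccc(C(=O)Nc2cc3ccc(OC4CCN(C)CC4)c(C)c3oc2=O)c1`) differs from compound 1 in one place: hydrogen in place of butoxy on an aromatic carbon, ortho to a 3-methylbut-2-en-1-yl group and para to a large group (hydrogen in place of butoxy on an aromatic carbon). For the measured compounds named here, no measured pair isolates this change, so its size cannot be read directly. Neither measured compound without butoxy reads beyond the scatter on the low side of compound 1: compound 3 gives 2000 nM and compound 2 gives 5010 nM. A modest rise in the number is therefore expected in this assay, possibly not beyond the scatter. The expected change is a 1.9-fold higher number from compound 1 to compound 4 (0.29 log units; within the scatter). For compound 4 the estimated value is 2800 nM, with an expected range from 1100 nM to 7000 nM.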

Compound 4, half-maximal inhibitory concentration: 2100 nM
Beside the measured number, compound 4's estimate is 1.3-fold (0.12 log units) above it; the range from low to high includes it.
By their numbers in this assay, from the lowest: compounds 1, 3 and 4 (each within the scatter of the next); then compound 2.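

In this assay, hydrogen in place of butoxy on this aromatic carbon, ortho to a 3-methylbut-2-en-1-yl group and para to a large group, gives a 1.5-fold higher number from compound 1 to compound 4 (0.16 log units; within the scatter), so the two compounds cannot be told apart. For the compounds shown here, this pair is the first to isolate the change, and it shows that with the 3-methylbut-2-en-1-yl group and the rest of the core kept, the butoxy group can be lost without a step beyond the scatter. No information is available on the cause of this result.

Still open, on these data alone, is how other groups on this carbon, such as methoxy, a longer alkoxy chain, an amine or a carboxylic acid, would read against butoxy and hydrogen. Also open, as far as these compounds go, is whether the same exchange would read alike with a propyl chain in place of the 3-methylbut-2-en-1-yl group.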